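Changing One Aryl Group on an Amide-Type Nitrogen

This account rests on a few compounds, and the source may have more. Where it says the series, first, only, none or still open, it means among the compounds named here.

Compound 2 (`O=C(Nc1ccc(C(F)(F)F)cc1)Nc1cc2ncncc2cc1OCc1cccc(Cl)c1`) gives 5100 nM in a functional assay on GBM3 cells (Homo sapiens) for antiproliferative activity, read by WST assay, with a stated time of 72 h (a lower number here means a stronger inhibitor, a higher number a weaker inhibitor), and compound 1 (`O=C(Nc1ccccc1F)Nc1cc2ncncc2cc1OCc1ccccc1`) gives 5900 nM in the same test, so the two stand level within the usual scatter. Compound 3 (`O=C(Nc1ccccc1F)Nc1cc2ncncc2cc1OCc1cccc(Cl)c1`) has 2-fluorophenyl in place of 4-(trifluoromethyl)phenyl on an amide-type nitrogen. Going by the values given here, no measured step isolates this change. The expected step of a 1.0-fold lower number from compound 2 to compound 3 (0.01 log units; within the scatter) stays within the scatter in this assay with no favoured direction, because compound 1 with the same 2-fluorophenyl gives 5900 nM in this test. For compound 3 the estimated value is 5000 nM with an expected range of 2500 nM to 10000 nM across repeat measurements.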

Compound 3, half-maximal inhibitory concentration: 7500 nM
Beside the measured number, compound 3's estimate is 1.5-fold (0.18 log units) below it; the range from low to high includes it.
By their numbers in this assay, from the lowest: compounds 2, 1 and 3 (each within the scatter of the next).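

In this assay, going by these compounds alone, the swap of 4-(trifluoromethyl)phenyl for 2-fluorophenyl on an amide-type nitrogen gives a 1.5-fold higher number from compound 2 to compound 3 (0.17 log units; within the scatter) and so stays inside the scatter, which is the first direct reading of this position. Chloro in place of hydrogen on an aromatic carbon gives a 1.3-fold higher number from compound 1 to compound 3 (0.10 log units; within the scatter) and also stays inside the scatter. Nothing measured here explains why these numbers stay level.

The compounds shown leave open whether a phenyl ring carrying an amine or a carboxylic acid, or a longer alkyl chain, on this nitrogen would move the number beyond the scatter. They also leave open how a methoxy group would compare with chloro on that aromatic carbon.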